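Compound 4, an Untested Analogue of Compound 2

The compounds below may be only part of what the source reports. "The series", "measured", "known", "first", "only" and "open" are said of these compounds alone.

Among the measured compounds shown here, in a functional assay on Jurkat cells (Homo sapiens) for inhibition (a lower number here means a stronger inhibitor, a higher number a weaker inhibitor), compound 2 `CC(C)[C@H](NC(=O)COc1cccc2ccccc12)C(=O)N[C@@H](CC(=O)O)C(=O)CSc1nnc(-c2ccccc2)o1` gives 150000 nM, the only number among the three values measured. Compound 1 `CC(C)[C@H](NC(=O)COc1cccc2ccccc12)C(=O)N[C@@H](CC(=O)O)C(=O)CSc1nc(-c2ccccc2)c(-c2ccccc2)o1` reaches only a limit of the assay, > 200000 nM. Compound 3 `CC(C)[C@H](NC(=O)COc1cccc2ccccc12)C(=O)N[C@@H](CC(=O)O)C(=O)COn1nnc2ccccc21` likewise reaches only a limit of the assay, > 200000 nM. For the measured compounds named here, the sole single-point step, an at least 1.3-fold higher number from compound 2 to compound 3 (0.12 log units; that floor lies within the scatter), therefore sets a floor rather than a size. Compound 4 `CC(C)[C@H](NC(=O)COc1cccc2ccccc12)C(=O)N[C@@H](CC(=O)O)C(=O)COc1ccccn1` differs from compound 2 by (pyridin-2-yl)oxy in place of (5-phenyl-1,3,4-oxadiazol-2-yl)sulfanyl on a saturated chain carbon bound to a carbonyl carbon. That change removes the same group as the change to compound 3, and the limit of > 200000 nM in this assay, at which 2 of the 3 values shown sit, bears on what can be seen. A weaker number is expected, with a step of a 1.7-fold higher number from compound 2 to compound 4 (0.22 log units; within the scatter), and a fair chance that only a limit is reported. Compound 4 is expected to give 250000 nM, between 100000 nM and 600000 nM.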

Compound 4, half-maximal inhibitory concentration: > 200000 nM
Compound 4 was reported as a limit (the forecaster's own chance of this, stated with the estimate: 65%); the middle value does not contradict the limit.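

On the saturated chain carbon bound to a carbonyl carbon, (pyridin-2-yl)oxy in place of (5-phenyl-1,3,4-oxadiazol-2-yl)sulfanyl gives in this assay an at least 1.3-fold higher number from compound 2 to compound 4 (0.12 log units; that floor lies within the scatter) and so sets only a floor, as the change to compound 3 did. The step between compound 3 and compound 4 cannot be read, since both are limits. Compound 2 remains the only compound here with a number, and the limit now holds most of the series: the limit of > 200000 nM in this assay, at which 3 of the 4 values shown sit.

Going by these compounds, what an amine or a longer chain at this place would give in this assay stays open. So does whether the floor hides a large step or a small one.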